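The source may report more compounds than this note shows. Statements on the series, on what has been measured and on what is new or still open speak of the compounds shown alone.

Of the compounds shown here, two with the same core have been measured in a functional assay on 786-0 cells (Homo sapiens) for cytotoxicity, read by sulforhodamine B assay, with a stated time of 48 h, tested at 0.01 uM; on this read-out lower numbers stand for a stronger effect and higher numbers for a weaker effect at the one concentration tested. Compound 1 `COc1cc(C)cc(-c2c(-c3ccnc(-c4ccc(C(C)=O)cc4)c3)cnn2CC#N)c1` gives 98% in this assay, a number close to the top of the scale, which on this read-out means little effect on the cells at the one concentration tested. Compound 2 `Cc1cc(O)cc(-c2nn(CC#N)cc2-c2ccnc(-c3ccc(Oc4ccccc4)cc3)c2)c1` gives 95% in this assay, and the two numbers lie within the usual scatter of each other, so nothing separates them. Compound 3 `COc1cc(C)cc(-c2c(-c3ccnc(-c4ccc(N(C)C)cc4)c3)cnn2CC#N)c1` has not yet been measured in this assay. It differs from compound 1 in one place: dimethylamino in place of acetyl on an aromatic carbon. Going by the values given here, since no measured pair shows what such a change does here, and both measured compounds sit near the top of the scale, the step from compound 1 to compound 3 is expected to be small, a number 1 percentage points lower from compound 1 to compound 3 (within the scatter), with no clear direction beyond the scatter. For compound 3 the expected value in this assay is 97%, with a range from 88% to 105%.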

Compound 3, a percentage reported as activity, at one concentration (the size of the read-out at that concentration, not a potency): 55%
Compound 3: the middle estimate sits 42 percentage points above what was measured, and the stated range ends above it.
By their numbers in this assay, from the lowest: compound 3; then compounds 2 and 1 (each within the scatter of the next).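

This position is not a silent one: the two groups have the same heavy-atom count and each carries one hydrogen-bond acceptor, yet in this assay putting dimethylamino in place of acetyl gives a number 43 percentage points lower from compound 1 to compound 3 (beyond the scatter). The change sits on an aromatic carbon of a six-membered aromatic ring of carbon only, para to a large group, and it turns a compound with little effect on the cells into one with a clear effect at the single concentration tested. Nothing available explains why this swap matters so much.

The compounds shown leave open whether a plain amino group, or diethylamino with its longer chains, would act like dimethylamino at this position. They also leave open whether the same swap would give a step of similar size in compound 2, which differs elsewhere too.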